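The compounds below may be only part of what the source reports. "The series", "measured", "known", "first", "only" and "open" are said of these compounds alone.

Compound 3 `COc1cc(Cl)cc(-c2nn(-c3cccc(NC(=O)Nc4ccc(Cl)c(Cl)c4)c3)cc2-c2ccncc2)c1` gives -10% in a functional assay on A549 cells (Homo sapiens) for inhibition, read by sulforhodamine B assay, with a stated time of 48 h, tested at 100 uM (on this read-out lower numbers stand for a stronger effect and higher numbers for a weaker effect at the one concentration tested), the highest of the three numbers measured; compound 2 `O=C(Nc1cccc(-n2cc(-c3ccncc3)c(-c3cc(O)cc(Cl)c3)n2)c1)Nc1ccc(Cl)c(Cl)c1` gives -32% and compound 1 `O=C(Nc1cccc(-n2cc(-c3ccncc3)c(-c3cc(O)cc(Cl)c3)n2)c1)Nc1ccc(Cl)c(C(F)(F)F)c1` gives -45%. Compound 4 `COc1cc(Cl)cc(-c2nn(-c3cccc(NC(=O)c4cccc(C(F)(F)F)c4)c3)cc2-c2ccncc2)c1` differs from compound 3 in one place: 3-(trifluoromethyl)phenyl in place of (3,4-dichlorophenyl)amino on a carbonyl carbon. The measured steps touch other parts of the molecule: a number 13 percentage points higher from compound 1 to compound 2 (beyond the scatter) and a number 22 percentage points higher from compound 2 to compound 3 (beyond the scatter), both modest and both rising toward compound 3. Neither concerns the carbonyl carbon changed here, so they give only a scale, not a direction. For compound 4 the expected step is a number 10 percentage points higher from compound 3 to compound 4 (within the scatter), with a wide allowance either way. Compound 4 is therefore estimated at 0% in this assay, between -30% and 25%.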

Compound 4, a percentage reported as activity, at one concentration (the size of the read-out at that concentration, not a potency): 30%
Compound 4: the middle estimate sits 30 percentage points below what was measured; the whole stated range lies below it.
By their numbers in this assay, from the lowest: compound 1; then compound 2; then compound 3; then compound 4.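

In this assay, the substituent on the carbonyl carbon proves to be a sensitive place: replacing (3,4-dichlorophenyl)amino with 3-(trifluoromethyl)phenyl gives a number 40 percentage points higher from compound 3 to compound 4 (beyond the scatter). This single change removes the amino nitrogen and its hydrogen-bond donor and also swaps the two chlorines for trifluoromethyl, so the step cannot be divided between these parts. Nothing available explains the step. Still open, from the compounds shown here alone, is how each part contributes, and how a small amine or a longer alkyl chain on that carbonyl carbon would compare.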